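The source may report more compounds than this note shows. Statements on the series, on what has been measured and on what is new or still open speak of the compounds shown alone.

Among the compounds with values here, in a functional assay on HCT-116 cells (Homo sapiens) for cytotoxicity, read by MTT assay, with a stated time of 72 h (on this read-out lower numbers stand for stronger inhibition and higher numbers for weaker inhibition), compound 1 `O=C1c2c[n+]([O-])c3ccccc3c2C(=O)c2c1c1ccccc1n2Cc1cn(C[C@H](O)CO)nn1` gives 400 nM and compound 2 `CC1(C)O[C@@H](CO)[C@H](Cn2cc(Cn3c4c(c5ccccc53)C(=O)c3c[n+]([O-])c5ccccc5c3C4=O)nn2)O1` gives 130 nM, the lower of the two numbers so far. Compound 3 `O=C1c2c[n+]([O-])c3ccccc3c2C(=O)c2c1c1ccccc1n2Cc1cn([C@@H]2O[C@H](CO)[C@@H](O)[C@H](O)[C@H]2O)nn1` changes the group on the aromatic nitrogen of the five-membered ring: 3,4,5-trihydroxy-6-(hydroxymethyl)oxan-2-yl in place of (5-(hydroxymethyl)-2,2-dimethyl-1,3-dioxolan-4-yl)methyl on an aromatic nitrogen. Within the data shown here, only one measured step bears on this: a 3.1-fold lower number from compound 1 to compound 2 (0.49 log units; beyond the scatter). There, the side chain bearing 1,2-dihydroxyethyl sat at the higher number, and the entering 3,4,5-trihydroxy-6-(hydroxymethyl)oxan-2-yl also carries free hydroxyl groups. A similar move towards a higher number is therefore expected in this assay, as the estimated 3.8-fold higher number from compound 2 to compound 3 (0.59 log units; beyond the scatter). For compound 3, the estimated value is 500 nM, with an expected range of 170 nM to 1500 nM.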

Compound 3, half-maximal inhibitory concentration: 130 nM
Beside the measured number, compound 3's estimate is 3.8-fold (0.59 log units) above it; the measured number lies below the stated range.
By their numbers in this assay, from the lowest: compounds 2 and 3 (each within the scatter of the next); then compound 1.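

In this assay, 3,4,5-trihydroxy-6-(hydroxymethyl)oxan-2-yl on the aromatic nitrogen in place of the dioxolane-bearing group gives no change at the digits printed from compound 2 to compound 3 (within the scatter) even though it carries free hydroxyl groups, so such groups do not in themselves go with the higher number of compound 1. Against 2,3-dihydroxypropyl, the same group gives a 3.1-fold lower number from compound 1 to compound 3 (0.49 log units; beyond the scatter) and thus separates two hydroxyl-bearing substituents. No measured evidence accounts for this result.

As far as these compounds go, whether an amine or a carboxylic acid on this aromatic nitrogen would stay level with compound 2 remains open. So does the effect of a longer chain between this nitrogen and the hydroxyl groups.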